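Oxazolopyridine ketones against diacylglycerol lipase-alpha: chain swap

The source may report more compounds than this note shows. Statements on the series, on what has been measured and on what is new or still open speak of the compounds shown alone.

compound 1 `O=C(CCCCCCc1ccccc1)c1ncno1`: > 10000 nM
compound 2 `O=C(CCCc1ccccc1)c1nc2ncccc2o1`: 2240 nM

In an assay on HEK-293T cells for inhibition of diacylglycerol lipase-alpha (Homo sapiens), read by colorimetric assay (a higher number here means a weaker inhibitor, a lower number a stronger inhibitor), compound 1 gives only > 10000 nM, which is a limit of the assay and not a number. In this assay, for the measured compounds named here, compound 2 gives 2240 nM, the only number so far. Going by the values given here, the one further value shown, that of compound 1, is a limit of the assay (the limit of > 10000 nM in this assay, at which 1 of the 2 values shown sits). Compound 3 `C=CCCCCCCCC(=O)c1nc2ncccc2o1` differs from compound 2 by hex-5-en-1-yl in place of phenyl on a saturated chain carbon, three bonds along the chain from a carbonyl carbon. Among the compounds with values here, no measured step bears on this change, so the expected step of a 1.1-fold higher number from compound 2 to compound 3 (0.05 log units; within the scatter) is none beyond the scatter. Compound 3 is estimated at 2500 nM, between 600 nM and 10000 nM.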

Compound 3, half-maximal inhibitory concentration: 550 nM
The estimate for compound 3 lay 4.5-fold (0.66 log units) above the measured number; the measured number lies below the stated range.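

In this assay, hex-5-en-1-yl in place of phenyl on a saturated chain carbon, three bonds along the chain from a carbonyl carbon, gives a 4.1-fold lower number from compound 2 to compound 3 (0.61 log units; beyond the scatter) and shows that this position needs no aromatic ring in this pair. The open chain, with the same count of 6 heavy atoms, gives the lower number. Nothing measured here bears on the reason for this step.

Still open, on these data alone, is how a saturated hexyl chain, a longer chain, an amine or a carboxylic acid would compare with hex-5-en-1-yl at this position. The double bond and the loss of the ring therefore remain unseparated.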